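A few compounds are considered here, and "the series" means these few. Any claim that something is new, unique, unknown or untested is made for them only; others in the source may bear on it.

Measured in an ADME assay on CCRF-HSB-2 cells (Homo sapiens) for cytotoxicity, with a stated time of 7 days; a higher number here means that more compound is tolerated, a lower number that less compound is tolerated:
Compound 1 `CNc1nc(N)nc2c1ncn2/C=C1/CC1(CO)CO`: > 20000 nM (a limit)
Compound 2 `CCCSc1nc(N)nc2c1ncn2/C=C1/CC1(CO)CO`: 98000 nM
Compound 3 `CCCNc1nc(N)nc2c1ncn2/C=C1/CC1(CO)CO`: > 20000 nM (a limit)

Compound 3 has no exact number, since compound 3 reads > 20000 nM, which is a limit. The results so far gather at the limit of > 20000 nM in this assay, at which 2 of the 3 values shown sit. Compound 4 `Nc1nc(NC2CCCC2)c2ncn(/C=C3/CC3(CO)CO)c2n1` has not yet been measured. It differs from compound 3 as follows: cyclopentyl in place of propyl on a nitrogen on an aromatic ring. In words, this is cyclopentyl in place of propyl on a nitrogen on an aromatic ring.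

The closest measured change is a step that the two limits leave unreadable from compound 1 to compound 3, with ethyl in place of hydrogen on a saturated chain carbon bound to a nitrogen on an aromatic ring. Also relevant is a step that the limit leaves unreadable from compound 2 to compound 3, with propylamino in place of propylsulfanyl on an aromatic carbon. Neither step has a readable size, so neither points in a direction, and no shift beyond the usual scatter is expected. The expected change is a step that the limit leaves unreadable from compound 3 to compound 4. The estimate for compound 4 is 40000 nM, expected to lie between 15000 nM and 100000 nM. A report as a limit alone would be no surprise.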

Compound 4, half-maximal cytotoxic concentration: > 20000 nM
Compound 4 gave a limit, no number; the forecaster's own chance of this, stated with the estimate: 70%; the middle value lies beyond the limit too.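

Compound 4 reads > 20000 nM, which is a limit and not a number. Within the data shown here, no step from compound 1, compound 2 or compound 3 to compound 4 can therefore be read. The compounds shown leave open whether cyclopentylamino and propylamino differ at all in how much compound the cells tolerate.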